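Swapping Chloro for Fluoro on a Thiosemicarbazone Pair

A few compounds are considered here, and "the series" means these few. Any claim that something is new, unique, unknown or untested is made for them only; others in the source may bear on it.

Of the compounds shown here, three share one core and have been tested in a functional assay on MCF7 cells (Homo sapiens) for cytotoxicity, read by MTT assay, with a stated time of 48 h; on this read-out lower numbers stand for stronger inhibition and higher numbers for weaker inhibition. Compound 1, `C/C(=N\NC(=S)Nc1ccc(Cl)cc1)c1ccccn1`, gives 8.49 nM. Compound 2, `C/C(=N\NC(=S)Nc1ccc(F)cc1)c1ccccn1`, gives 1.2 nM. Compound 3, `CC(=NNC(=S)Nc1ccc(Cl)cc1)c1ccccn1`, gives 8.5 nM. The fourth, compound 4, `CC(=NNC(=S)Nc1ccc(F)cc1)c1ccccn1`, has not yet been measured.

Compounds 1 and 3 differ only in how they are drawn: the two compounds have the same atoms and bonds; at least one stereo element is drawn with a configuration in one of them and without one in the other: 1 of 1 stereo elements differ; a double bond is drawn E in compound 1 and without a configuration in compound 3. Their values lie a 1.0-fold higher number from compound 1 to compound 3 (0.00 log units; within the scatter), which fits with the fact that one of compounds 1 and 3 is drawn with a defined configuration and the other without, at the place where they differ, so the two may be treated as the same substance in this assay.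

The change from compound 1 to compound 2 is fluoro in place of chloro on an aromatic carbon. It gave a 7.1-fold lower number from compound 1 to compound 2 (0.85 log units; beyond the scatter), a clear gain in potency.

The change from compound 3 to compound 4 is the same one: fluoro in place of chloro on an aromatic carbon. Since compound 3 and compound 1 agree within the scatter, and compound 2 already shows what this fluoro-for-chloro swap does on this core, compound 4 is expected to behave much like compound 2. The step is therefore estimated as a 6.5-fold lower number from compound 3 to compound 4 (0.82 log units; beyond the scatter), resting on the measured step from compound 1 to compound 2 of a 7.1-fold lower number from compound 1 to compound 2 (0.85 log units; beyond the scatter) and on compound 3 giving 8.5 nM. For the measured compounds named here, with only one such precedent, some spread must be allowed. On that basis compound 4 is estimated at 1.3 nM, with the likely range from 0.5 nM to 3.5 nM.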

Compound 4, half-maximal inhibitory concentration: 1.2 nM
Beside the measured number, compound 4's estimate is 1.1-fold (0.03 log units) above it; the measured number falls inside the stated range.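

In this assay, fluoro in place of chloro gave a 7.1-fold lower number from compound 3 to compound 4 (0.85 log units; beyond the scatter), which agrees with the earlier step: the same change on two cores in this assay, a 7.1-fold lower number (0.85 log units; beyond the scatter) from compound 1 to compound 2 and a 7.1-fold lower number (0.85 log units; beyond the scatter) from compound 3 to compound 4, 1.0-fold (0.00 log units) apart, within the scatter of two such steps. The new value also shows no change at the digits printed from compound 2 to compound 4 (within the scatter), so this second pair looks like a repeat of the first rather than a test on a truly different core, as compound 2 and compound 4 have the same atoms and bonds: the fact that one of compounds 2 and 4 is drawn with a defined configuration and the other without, at the place where they differ. The agreement therefore shows that the gain from this swap is reproducible when the double bond is drawn with or without a configuration, but it does not show that the gain would carry over to a core with different atoms, and the same caution applies to the chloro pair: the fact that one of compounds 1 and 3 is drawn with a defined configuration and the other without, at the place where they differ.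

The compounds shown leave open how other groups at the same place on the aromatic ring, such as bromo, methyl, methoxy or an amine, would compare with chloro and fluoro. They also leave open whether the fluoro-for-chloro gain would survive a change elsewhere in the shared core, such as replacing the sulfur of the thiourea-like part with oxygen or lengthening the methyl group to an ethyl chain.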